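The compounds below may be only part of what the source reports. "The series", "measured", "known", "first", "only" and "open" are said of these compounds alone.

Going by the values given here, in a toxicity assay on MT4 cells (Homo sapiens) for cytotoxicity, read by MTT assay (a higher number here means that more compound is tolerated, a lower number that less compound is tolerated), compound 1 `Cc1cc(-c2ccc(F)cc2)cc(C)c1Oc1cc(N)nc(Nc2ccc(C#N)cc2)n1` gives 23100 nM and compound 2 `COc1cccc(-c2cc(C)c(Oc3cc(N)nc(Nc4ccc(C#N)cc4)n3)c(C)c2)c1` gives 19300 nM, so compound 2 stands within the usual scatter of the only other number available. Compound 3 `Cc1cc(-c2ccccc2C#N)cc(C)c1Oc1cc(N)nc(Nc2ccc(C#N)cc2)n1` has 2-cyanophenyl in place of 3-methoxyphenyl on an aromatic carbon. Among the compounds with values here, one measured step bears on this change, the swap of 4-fluorophenyl for 3-methoxyphenyl at the same place, a 1.2-fold lower number from compound 1 to compound 2 (0.08 log units; within the scatter). That step is small, so no change beyond the scatter is expected in this assay. The expected step is a 1.0-fold higher number from compound 2 to compound 3 (0.02 log units; within the scatter). For compound 3 the estimated value is 20000 nM, with an expected range of 10000 nM to 40000 nM.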

Compound 3, half-maximal cytotoxic concentration: 25400 nM
The estimate for compound 3 lay 1.3-fold (0.10 log units) below the measured number, and the stated range covers the measured number.
By their numbers in this assay, from the lowest: compounds 2, 1 and 3 (each within the scatter of the next).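

In this assay, going by these compounds alone, swapping in 2-cyanophenyl gives no step that can be told from scatter: a 1.3-fold higher number from compound 2 to compound 3 (0.12 log units; within the scatter) and a 1.1-fold higher number from compound 1 to compound 3 (0.04 log units; within the scatter) are both within it. Within the data shown here, the first two compounds showed this for only one pair of groups; now three different aromatic groups at this place, with a nitrile among them, give numbers that cannot be separated. Nothing shown gives a cause for this. From the compounds shown here alone, it stays open whether a non-aromatic group here, such as an amine, a carboxylic acid or a longer chain, would read the same.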